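From a Bare Ring Position to a Hydroxyalkyne Arm

The source may hold more compounds than are shown below. What is called first, only, known or untested is meant among the compounds shown, and "the series" means these compounds.

Going by the values given here, compound 2 `CN1CCC[C@H]1COc1cccnc1` gives 7.7 nM in an assay on a protein complex for binding affinity to Neuronal acetylcholine receptor; alpha3/beta2 (Homo sapiens) (on this read-out higher numbers stand for weaker inhibition and lower numbers for stronger inhibition), the lowest of the two numbers measured so far, with compound 1 `C#Cc1cncc(OC[C@@H]2CCCN2C)c1` nearest at 8.2 nM. Compound 3 `CN1CCC[C@H]1COc1cncc(C#CCO)c1` differs from compound 2 by 3-hydroxyprop-1-yn-1-yl in place of hydrogen on an aromatic carbon. Among the compounds with values here, the only measured step at this position is a 1.1-fold lower number from compound 1 to compound 2 (0.03 log units; within the scatter), which lay within the scatter, so a small group there left the number essentially unchanged. From the compounds shown here alone, the longer arm with its hydroxyl is untested here, so only a modest shift is expected. Compound 3 is therefore estimated at 12 nM, between 4 nM and 40 nM. The expected step is a 1.6-fold higher number from compound 2 to compound 3 (0.19 log units; within the scatter).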

Compound 3, inhibition constant: 7.1 nM
Estimate against measurement, compound 3: 1.7-fold (0.23 log units) above; measured number inside the range.
By their numbers in this assay, from the lowest: compounds 3, 2 and 1 (each within the scatter of the next).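

In this assay, putting the 3-hydroxyprop-1-yn-1-yl arm on the bare aromatic carbon gives a 1.1-fold lower number from compound 2 to compound 3 (0.04 log units; within the scatter) and shows that this position takes an arm of several heavy atoms, not only the ethynyl of compound 1, without a change beyond the scatter. Extending that ethynyl with hydroxymethyl on the triple-bonded carbon gives a 1.2-fold lower number from compound 1 to compound 3 (0.06 log units; within the scatter) and likewise leaves the number within the scatter. From the compounds shown here alone, whether a longer chain, an amine or a carboxylic acid at the end of the triple bond would keep the number in this range stays open. No data here explain why these three numbers lie so close.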